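The source may hold more compounds than are shown below. What is called first, only, known or untested is meant among the compounds shown, and "the series" means these compounds.

Of the compounds shown here, two have been measured in a functional assay on NSCLC cells (Homo sapiens) for cytotoxicity, with a stated time of 48 h; a lower number here means a stronger inhibitor of growth, a higher number a weaker inhibitor of growth. Compound 1 `COc1c(/C=C2/C(=O)Nc3ccccc32)c2ccccc2n1-c1ccccc1` gives 8320 nM, the lower of the two numbers; compound 2 `COc1ccc2c(c1)/C(=C\c1c(Cl)n(C/C=C/c3ccccc3)c3ccccc13)C(=O)N2` gives 37200 nM, a higher number that lies beyond the usual scatter. Compound 3 `COc1c(/C=C2/C(=O)Nc3ccc(Cl)cc32)c2ccccc2n1-c1ccccc1` differs from compound 1 by one change, (chloro in place of hydrogen on an aromatic carbon). For the measured compounds named here, no measured pair shows this step, so the expectation rests on compound 1 alone: the step is expected to be small, a 1.2-fold lower number from compound 1 to compound 3 (0.08 log units; within the scatter), and to stay within the scatter in either direction. Compound 3 is therefore estimated at 7000 nM, between 2500 nM and 20000 nM in this assay.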

Compound 3, concentration for total growth inhibition: 24600 nM
The estimate for compound 3 lay 3.5-fold (0.55 log units) below the measured number, and the stated range ends below it.
By their numbers in this assay, from the lowest: compound 1; then compounds 3 and 2 (each within the scatter of the next).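

In this assay, chloro in place of hydrogen on an aromatic carbon of the fused system gives a 3.0-fold higher number from compound 1 to compound 3 (0.47 log units; beyond the scatter), a change toward weaker inhibition of growth. This shows that the position is not indifferent to substitution: one chlorine atom is enough to move the number beyond the scatter. Nothing available explains this step.

From the compounds shown here alone, whether fluoro, an amine or a carboxylic acid at this same place would also raise the number remains open. So does whether chloro would have the same effect elsewhere on the shared core.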